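The compounds below may be only part of what the source reports. "The series", "measured", "known", "first", "only" and "open" are said of these compounds alone.

Compound 2 `C[C@H](c1ccc(C(=O)NCCC(=O)O)cc1)N1C(=O)C(c2cccc(Cl)c2)=N[C@]12CC[C@@H](C(C)(C)C)CC2` gives 3300 nM in an assay on membranes from liver for displacement of a labelled ligand from Glucagon receptor (Mus musculus), read by scintillation counting, with a stated time of 60 min; a higher number here means a weaker inhibitor, a lower number a stronger inhibitor. Compound 1 `C[C@H](c1ccc(C(=O)NCCC(=O)O)cc1)N1C(=O)C(c2ccc(F)cc2)=N[C@]12CC[C@@H](C(C)(C)C)CC2` gives 2500 nM in this assay; the step of a 1.3-fold higher number from compound 1 to compound 2 (0.12 log units; within the scatter) lies within the scatter, so the two stand level and compound 2 is not set apart by its number. Compound 3 `C[C@H](c1ccc(C(=O)NCCC(=O)O)cc1)N1C(=O)C(c2ccccc2F)=N[C@]12CC[C@@H](C(C)(C)C)CC2` is unmeasured. The change is 2-fluorophenyl in place of 3-chlorophenyl on a carbon with a double bond to nitrogen. For the measured compounds named here, only the step from compound 1 to compound 2 bears on it, an exchange of one halogenated phenyl for another with no movement beyond the scatter, so no movement beyond the scatter is expected in this assay here either, a 1.1-fold lower number from compound 2 to compound 3 (0.04 log units; within the scatter). Compound 3 is estimated at 3000 nM, within 1200 nM to 8000 nM.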

Compound 3, half-maximal inhibitory concentration: > 10000 nM
Compound 3: no number, only a limit; the forecaster's own chance of this, stated with the estimate: 10%; at least 3.3-fold (0.52 log units) between middle value and limit.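

Compound 3 carries only a limit of the assay, not a number: the limit of > 10000 nM in this assay, at which 1 of the 3 values shown sits. The halogenated phenyl on the carbon with a double bond to nitrogen therefore cannot be exchanged freely in this assay: 2-fluorophenyl gives an at least 3.0-fold higher number from compound 2 to compound 3 (0.48 log units; beyond the scatter) and an at least 4.0-fold higher number from compound 1 to compound 3 (0.60 log units; beyond the scatter), although 3-chlorophenyl and 4-fluorophenyl stand level. The step to compound 3 changes both the halogen and its ring position in one exchange from compound 2, and only the ring position from compound 1.

From the compounds shown here alone, whether 2-chlorophenyl behaves like 2-fluorophenyl remains open, and so does the standing of unsubstituted phenyl. The compounds shown also leave open how 3-fluorophenyl compares with 3-chlorophenyl.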